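Swapping the aryl ring on a triazole-thiol hydrazone series

The source may report more compounds than this note shows. Statements on the series, on what has been measured and on what is new or still open speak of the compounds shown alone.

Three hydrazones have been measured in a functional assay, with a stated time of 30 min; on this read-out higher numbers stand for weaker inhibition and lower numbers for stronger inhibition. Compound 1 `CN(C)c1ccc(/C=N/n2c(S)nnc2-c2cnccn2)cc1` gives 14000 nM. Compound 2 `Oc1ccccc1/C=N/n1c(S)nnc1-c1cnccn1` gives 75900 nM, and compound 3 `Oc1ccc(/C=N/n2c(S)nnc2-c2cnccn2)c(O)c1` gives 75900 nM; the step of no change at the digits printed from compound 2 to compound 3 (within the scatter) shows that the added hydroxy left the read-out unchanged. Compound 2 therefore stands level with compound 3 at the highest numbers, while compound 1 sits well lower.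

Compound 4 `Fc1ccc(/C=N/n2c(S)nnc2-c2cnccn2)cc1` arises from compound 2 by the change (4-fluorophenyl in place of 2-hydroxyphenyl on a carbon with a double bond to nitrogen). For the measured compounds named here, no measured step covers this exact exchange; the only nearby step is the unchanged one from compound 2 to compound 3. Compound 4 is thus expected near compound 2, with the estimated step of a 1.9-fold lower number from compound 2 to compound 4 (0.28 log units; within the scatter) pointing, if anywhere, slightly toward compound 1. The expected value for compound 4 is 40000 nM, in the range 12000 nM to 120000 nM.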

Compound 4, half-maximal inhibitory concentration: 58800 nM
Compound 4: middle estimate off by 1.5-fold (0.17 log units), on the low side, within the range that was stated.
By their numbers in this assay, from the lowest: compound 1; then compounds 4, 2 and 3 (each within the scatter of the next).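

In this assay, the step with 4-fluorophenyl in place of 2-hydroxyphenyl on a carbon with a double bond to nitrogen is a 1.3-fold lower number from compound 2 to compound 4 (0.11 log units; within the scatter) and so this position tolerated the exchange, even with the leaving group's hydrogen-bond donor and acceptor gone. Fluoro in place of dimethylamino on an aromatic carbon gives a 4.2-fold higher number from compound 1 to compound 4 (0.62 log units; beyond the scatter) and so dimethylamino is the one exchange here that separates two compounds. Nothing available explains either step.

As far as these compounds go, whether another amine, such as pyrrolidine or a plain amino group, would match compound 1 remains open, as does the outcome with a carboxylic acid on the aryl ring.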